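A few compounds are considered here, and "the series" means these few. Any claim that something is new, unique, unknown or untested is made for them only; others in the source may bear on it.

Measured in a physicochemical assay for lipophilicity, in phosphate buffer, measured as octanol-water partition, at pH 11.5; on this read-out higher numbers stand for higher lipophilicity and lower numbers for lower lipophilicity:
- compound 1 `CCCCOC(=N)NC(=N)Nc1ccc(Cl)cc1`: 3.32
- compound 2 `CCCCCCCCNC(=N)NC(=N)Nc1ccc(Cl)cc1`: 5.13
- compound 3 `CCOC(=N)NC(=N)Nc1ccc(Cl)cc1`: 2.32

Of these three, compound 3 has the lowest number, at 2.32, and compound 2 has the highest, at 5.13. The next compound, compound 4 `CNC(=N)NC(=N)Nc1ccc(Cl)cc1`, has not yet been measured in this assay. It carries methylamino in place of ethoxy on a carbon with a double bond to nitrogen.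

For the measured compounds named here, no measured step covers this exchange directly. The closest evidence is the change from butoxy to ethoxy, a number 1.00 log units lower from compound 1 to compound 3 (beyond the scatter). Going by the values given here, compound 2, with octylamino, is the only measured compound that has an amino group in this place, so ethoxy and an amino group are never compared at matched chain length. On the strength of a number 1.00 log units lower from compound 1 to compound 3 (beyond the scatter), a downward step somewhat smaller than that one is expected, though still beyond the scatter. The estimated change is a number 0.62 log units lower from compound 3 to compound 4 (beyond the scatter). Compound 4 is expected at 1.7, with an estimated range from 1.1 to 2.3.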

Compound 4, partition coefficient: 1.58
Beside the measured number, compound 4's estimate is 0.12 log units above it; low and high end bracket the measured number.
By their numbers in this assay, from the lowest: compound 4; then compound 3; then compound 1; then compound 2.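

In this assay the exchange of ethoxy for methylamino on a carbon with a double bond to nitrogen now has a direct reading of a number 0.74 log units lower from compound 3 to compound 4 (beyond the scatter) and leaves compound 4 with the lowest number of the four. The exchange of butoxy for methylamino at the same place gives a number 1.74 log units lower from compound 1 to compound 4 (beyond the scatter) and is larger, so the size of the drop depends on the chain that leaves. With the amine nitrogen kept in place, the first chain shortening on the amino side gives a number 3.55 log units lower from compound 2 to compound 4 (beyond the scatter) and is the largest step in the set.

The step from compound 3 changes the oxygen to nitrogen and the chain length together, and an ethylamino or butylamino group at this place would be needed to separate the two. Nothing shown here gives a cause for these steps.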